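Heteroaryl swap on the core of compound 1

A few compounds are considered here, and "the series" means these few. Any claim that something is new, unique, unknown or untested is made for them only; others in the source may bear on it.

Compound 1 `Cc1ccnc(-c2cnc(C(=O)CCCCCCc3ccccc3)o2)c1` gives 0.6 nM in an assay (Rattus norvegicus) for inhibition of Fatty-acid amide hydrolase 1 (Homo sapiens) (a higher number here means a weaker inhibitor, a lower number a stronger inhibitor), the lowest of the three numbers at hand. Compound 2 `O=C(CCCCCCc1ccccc1)c1ncc(-c2cc(C(F)(F)F)ccn2)o1` gives 3.5 nM; the step of a 5.8-fold higher number from compound 1 to compound 2 (0.77 log units; beyond the scatter) is modest but clear. Compound 3 `COc1ncc(-c2cnc(C(=O)CCCCCCc3ccccc3)o2)c(OC)n1` gives 26 nM, a much weaker result than compound 1. Compound 4 `O=C(CCCCCCc1ccccc1)c1ncc(-c2cc(=O)[nH]c(=O)[nH]2)o1` is not yet measured; its change from compound 1 is a group of 8 heavy atoms (4 carbon, 2 nitrogen, 2 oxygen; one six-membered aromatic ring with 2 hetero atoms) in place of a group of 7 heavy atoms (6 carbon, 1 nitrogen; one six-membered aromatic ring with 1 hetero atom), on an aromatic carbon. Among the measured compounds shown here, only the step from compound 1 to compound 2 bears on this, and loosely, since it keeps the ring and alters a substituent, whereas compound 3 shows how far a different six-membered ring can move the number. A step at least as large as a 5.8-fold higher number from compound 1 to compound 2 (0.77 log units; beyond the scatter), toward a higher number, is expected. The estimate for compound 4 is 40 nM with a range of 8 nM to 250 nM. This expected shift amounts to a 67-fold higher number from compound 1 to compound 4 (1.82 log units; beyond the scatter).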

Compound 4, inhibition constant: 12 nM
For compound 4 the middle estimate is 3.3-fold (0.52 log units) above the measured one, within the range that was stated.
By their numbers in this assay, from the lowest: compound 1; then compound 2; then compound 4; then compound 3.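

In this assay, the place next to the ring oxygen accepts a full exchange of the 4-methylpyridin-2-yl ring for a ring with two hydrogen-bond donors, but at a large cost: a 20-fold higher number from compound 1 to compound 4 (1.30 log units; beyond the scatter). Even so, compound 4 gives 12 nM, so this place is open to a ring carrying two double bonds outside the aromatic ring. No available evidence accounts for the loss.

Which part of the exchange carries the loss remains open. A pyridin-2-yl ring bearing an amine or a carboxylic acid at the same place would help separate the ring from its substituents.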